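The source may report more compounds than this note shows. Statements on the series, on what has been measured and on what is new or still open speak of the compounds shown alone.

In a functional assay on PC-9 cells (Homo sapiens) for inhibition, read by MTT assay, with a stated time of 48 h, tested at 10 uM (on this read-out higher numbers stand for more inhibition at the one concentration tested (going by the name of the read-out) and lower numbers for less inhibition), compound 1 `COc1cc(NC(=O)Nc2cc(Nc3ccc(OC)c(C)c3)ncn2)cc(OC)c1` gives 62%, compound 2 `COc1cc(NC(=O)Nc2cc(Nc3cc(C)cc(F)c3)ncn2)cc(OC)c1` gives 64.5% and compound 3 `COc1cc(Nc2cc(NC(=O)Nc3c(Cl)cccc3Cl)ncn2)cc(C(F)(F)F)c1` gives 88.5%. Compound 2 thus stands within the scatter of compound 1 and well short of compound 3. Compound 4 `COc1cc(NC(=O)Nc2cc(Nc3cc(I)ccc3OC)ncn2)cc(OC)c1` differs from compound 2 in one place: 5-iodo-2-methoxyphenyl in place of 3-fluoro-5-methylphenyl on a nitrogen on an aromatic ring. Within the data shown here, the only measured step at this position, a number 2.5 percentage points higher from compound 1 to compound 2 (within the scatter), stayed within the scatter, and no other measured pair changes this group alone, so the account has that single step to lean on; compound 3 differs in more than one place and does not bear on it. On that basis the expected step in this assay is a number 2.5 percentage points lower from compound 2 to compound 4 (within the scatter), nothing beyond the scatter. Compound 4 is therefore estimated at 62%, with a range from 42% to 80%.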

Compound 4, a percentage reported as inhibition, at one concentration (the size of the read-out at that concentration, not a potency): 91%
Compound 4: the middle estimate sits 29 percentage points below what was measured, and the stated range ends below it.
By their numbers in this assay, from the lowest: compounds 1 and 2 (each within the scatter of the next); then compounds 3 and 4 (each within the scatter of the next).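

In this assay, the aryl group on this nitrogen can matter: 5-iodo-2-methoxyphenyl in place of 3-fluoro-5-methylphenyl gives a number 26.5 percentage points higher from compound 2 to compound 4 (beyond the scatter), and in place of 4-methoxy-3-methylphenyl it gives a number 29 percentage points higher from compound 1 to compound 4 (beyond the scatter). The earlier change at this position had stayed within the scatter, so this position is not indifferent to every change of aryl group. Nothing available explains why this group stands apart from the other two.

The compounds shown do not separate the contribution of the iodo group from that of the methoxy group. They also leave open how a phenyl ring carrying an amine or a carboxylic acid would read at this position.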